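The compounds below may be only part of what the source reports. "The series", "measured", "known", "first", "only" and "open" are said of these compounds alone.

Compound 1 `CC(C)COc1ncc(-c2cn(C)c3cc(C(=O)NS(C)(=O)=O)ccc23)cc1Cl` is measured in an ADME assay on a cell-free system (plasma, Homo sapiens) for protein binding (on this read-out higher numbers stand for a larger free fraction and lower numbers for a smaller free fraction), and gives < 0.001, which is a limit of the assay rather than a number.
Compound 2 `CC(C)COc1ncc(-c2cn(C)c3cc(C(=O)NS(C)(=O)=O)c(F)cc23)cc1Cl` gives 0.001 in this assay.
Compound 3 `Cn1cc(-c2ccc(C(F)(F)F)cc2)c2cc(F)c(C(=O)NS(C)(=O)=O)cc21` gives 0.002 in this assay.

Compounds 1 and 2 share one core; compound 3 has another, and the difference between the two cores is not broken down here. From compound 2 to compound 1 the change is hydrogen in place of fluoro on an aromatic carbon, and the step is a number no higher from compound 2 to compound 1 (the limit leaves the size open); its size is not readable because of the limit of < 0.001 in this assay, at which 1 of the 3 values shown sits. Compound 3 and compound 2 lie within the usual scatter of each other.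

Compound 4 `Cn1cc(-c2ccc(C(F)(F)F)cc2)c2ccc(C(=O)NS(C)(=O)=O)cc21` is not yet measured. It differs from compound 3 by hydrogen in place of fluoro on an aromatic carbon, the same change as from compound 2 to compound 1. Since that step gave no readable size, the step from compound 3 to compound 4 is expected to be small, about a 1.3-fold lower number from compound 3 to compound 4 (0.12 log units; within the scatter). Compound 4 is therefore estimated at 0.0015, with a range from 0.0007 to 0.003.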

Compound 4, unbound fraction: < 0.001
Compound 4 was reported as a limit; the forecaster's own chance of this, stated with the estimate: 25%; middle value at least 1.5-fold (0.17 log units) away from the limit.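

On the core of compound 3, hydrogen in place of fluoro on an aromatic carbon gives an at least 2.0-fold lower number from compound 3 to compound 4 (0.30 log units; that floor lies within the scatter) in this assay. On neither core does the change give a higher number, so the direction holds for these two pairs, but this does not show that its size carries from one core to the other: the same change on two cores in this assay, a number no higher (the limit leaves the size open) from compound 2 to compound 1 and an at least 2.0-fold lower number (0.30 log units; that floor lies within the scatter) from compound 3 to compound 4; the limit leaves it open whether they differ Both steps end at a limit of the assay, which leaves neither with a full size of its own: the limit of < 0.001 in this assay, at which 2 of the 4 values shown sit.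

The compounds shown leave open what a chloro or methoxy group on that same aromatic carbon would do. They also leave open whether a carboxylic acid in place of the (methylsulfonyl)carbamoyl group would move the unbound fraction clear of the limit.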